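Chalcone-type series: dihalophenyl swap on the carbonyl carbon

The source may hold more compounds than are shown below. What is called first, only, known or untested is meant among the compounds shown, and "the series" means these compounds.

Measured so far:
compound 1, `COc1cc(-c2cc(/C=C/C(=O)c3ccc(Cl)c(Cl)c3)[nH]n2)cc(OC)c1OC`, 92%
compound 2, `COc1ccc(C(=O)/C=C/c2cc(-c3cc(OC)c(OC)c(OC)c3)n[nH]2)cc1OC`, 76%

Working notes. Among the compounds with values here, in a functional assay on BT-549 cells (Homo sapiens) for cytotoxicity, read by sulforhodamine B assay, with a stated time of 48 h, tested at 1 uM (on this read-out higher numbers stand for a weaker effect at the one concentration tested and lower numbers for a stronger effect), compound 1 gives 92%, the highest of the two numbers so far, which on this read-out means the weakest effect at the one concentration tested. Within the data shown here, compound 2 is the nearest measured neighbour; the only measured step is a number 16 percentage points lower from compound 1 to compound 2 (beyond the scatter), and it consists of a 3,4-dimethoxyphenyl in place of a 3,4-dichlorophenyl on the carbonyl carbon.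

Compound 3 is `COc1cc(-c2cc(/C=C/C(=O)c3ccc(F)c(F)c3)[nH]n2)cc(OC)c1OC`. It differs from compound 1 as follows: 3,4-difluorophenyl in place of 3,4-dichlorophenyl on a carbonyl carbon. Among the measured compounds shown here, no measured step exchanges one dihalophenyl for another; the step from compound 1 to compound 2 replaces the same group with a different one and is therefore only a loose guide. It shows that a change at this position can move the read-out by a modest amount, and nothing more. The expectation for compound 3 is accordingly a small downward step, a number 5 percentage points lower from compound 1 to compound 3 (within the scatter), within or barely beyond the scatter. The estimate for compound 3 in this assay is 87%, with a range from 72% to 100%.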

Compound 3, a percentage reported as activity, at one concentration (the size of the read-out at that concentration, not a potency): 92%
For compound 3 the middle estimate is 5 percentage points below the measured one; the range from low to high includes it.
By their numbers in this assay, from the lowest: compound 2; then compounds 1 and 3 (each within the scatter of the next).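

In this assay, exchanging 3,4-dichlorophenyl for 3,4-difluorophenyl on the carbonyl carbon gives no change at the digits printed from compound 1 to compound 3 (within the scatter), so this read-out does not separate these two dihalophenyl groups at this position, a comparison that the earlier pair could not offer. The second new step, a number 16 percentage points higher from compound 2 to compound 3 (beyond the scatter), means that the 3,4-dimethoxyphenyl group of compound 2 now stands apart from two dihalophenyl groups rather than from one, and compound 2 shows the strongest effect of the three at the one concentration tested, though only by a modest margin. No available evidence bears on what lies behind these readings at this position.

Still open, going by these compounds, is whether the separation of compound 2 needs both methoxy groups, and how a phenyl ring carrying a single methoxy group, a carboxylic acid or a dimethylamino group would read on the same carbonyl carbon. On these data alone, a read-out at one concentration also gives no potency for any of the three compounds, and all of them share the same core, so the effect of changes elsewhere in the structure remains open too.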